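This account rests on a few compounds, and the source may have more. Where it says the series, first, only, none or still open, it means among the compounds named here.

Measured compounds:
compound 1 `Cc1ccc2nc(N3CCCc4ccccc4C3)cc(NCCN)c2c1` — 9400 nM
compound 2 `CS(=O)(=O)c1ccc2nc(N3CCCc4ccccc4C3)cc(NCCN)c2c1` — 13000 nM
compound 3 `Cc1ccc2nc(N3CCCc4ccc(F)cc4C3)cc(NCCN)c2c1` — > 3200 nM

In an ADME assay on HEp-2 cells (Homo sapiens) for cytotoxicity, read by CCK-8 assay, with a stated time of 5 days (on this read-out higher numbers stand for lower toxicity in this test and lower numbers for higher toxicity in this test), compound 1 gives 9400 nM. Compound 2 gives 13000 nM, and the step of a 1.4-fold higher number from compound 1 to compound 2 (0.14 log units; within the scatter). For compound 3 the result is only a limit, > 3200 nM, one of the readings that sits at the limit of the test (the limit of > 3200 nM in this assay, at which 1 of the 3 values shown sits). Because of this limit the step that the limit leaves unreadable from compound 1 to compound 3 cannot be sized, and compound 3 cannot be placed relative to compound 1 or compound 2 beyond the fact that it is not more toxic than the limit allows.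

Compound 4 `Cc1ccc2nc(N3CCCc4ccc(F)cc4C3)cc(NC3(CN)COC3)c2c1` differs from compound 3 by 3-(aminomethyl)oxetan-3-yl in place of 2-aminoethyl on a nitrogen on an aromatic ring. Going by the values given here, none of the measured steps touches this part of the structure: both concern groups on aromatic carbons, and the only one that can be read, from compound 1 to compound 2, stays within the scatter. Among the compounds with values here, with no step speaking to this change, the step that the limit leaves unreadable from compound 3 to compound 4 is expected to stay within the scatter of where the series sits. Compound 4 is therefore estimated at 9000 nM, with a range from 3000 nM to 30000 nM.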

Compound 4, half-maximal cytotoxic concentration: 86000 nM
Compound 4: the middle estimate sits 9.6-fold (0.98 log units) below what was measured; measured number above the stated range.
By their numbers in this assay, from the lowest: compounds 1 and 2 (each within the scatter of the next); then compound 4.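

In this assay the step from compound 3 to compound 4 cannot be read, because compound 3 stands only as a limit: the limit of > 3200 nM in this assay, at which 1 of the 4 values shown sits. The compounds shown leave open in which direction, and how far, 3-(aminomethyl)oxetan-3-yl in place of 2-aminoethyl moves the number.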